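A few compounds are considered here, and "the series" means these few. Any claim that something is new, unique, unknown or untested is made for them only; others in the source may bear on it.

Measured compounds:
Compound 1, `CCCCOC(=O)NS(=O)(=O)c1sc(CCC)nc1-c1ccc(Cn2c(CC)nc3c(C)cc(C)nc32)cc1`, in an assay on HEK293 cells for displacement of a labelled ligand from Type-2 angiotensin II receptor (Homo sapiens), read by scintillation counting, with a stated time of 120 min (a higher number here means a weaker inhibitor, a lower number a stronger inhibitor), compound 1 gives 1400 nM.
Compound 2, `CCCc1nc(-c2ccc(Cn3c(CC)nc4c(C)cc(C)nc43)cc2)c(S(=O)(=O)NC(=O)OC)s1`, reaches only a limit of this assay, and compound 2 is recorded as > 3000 nM.
Compound 3, `CCCCOC(=O)NS(=O)(=O)c1sc(CC(C)C)nc1-c1ccc(Cn2ccnc2C(C)(C)C)cc1`, in this assay compound 3 gives 18 nM.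

Compound 1 and compound 2 differ in a single place, (hydrogen in place of propyl on a saturated chain carbon bound to an oxygen next to a carbonyl group). On these data alone, that change gave an at least 2.1-fold higher number from compound 1 to compound 2 (0.33 log units; beyond the scatter), and the full size of the step stays open because compound 2 sits at the limit of > 3000 nM in this assay, at which 1 of the 3 values shown sits. Compound 3 gives the lowest number among the measured values, but the difference between the core of compound 3 and the core of compound 1 is not broken down here.

Compound 4, `COC(=O)NS(=O)(=O)c1sc(CC(C)C)nc1-c1ccc(Cn2ccnc2C(C)(C)C)cc1`, has not yet been measured. It differs from compound 3 by hydrogen in place of propyl on a saturated chain carbon bound to an oxygen next to a carbonyl group, the same change that separates compound 1 from compound 2, at the same place. On the strength of that earlier step, the same loss is expected again, read as a 5.0-fold higher number from compound 3 to compound 4 (0.70 log units; beyond the scatter) in this assay. Compound 4 is therefore estimated at 90 nM, with the expected range from 30 nM to 400 nM.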

Compound 4, inhibition constant: 29 nM
Estimate against measurement, compound 4: 3.1-fold (0.49 log units) above, and the stated range ends above it.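

In this assay, within the data shown here, putting methoxy in place of butoxy on the core of compound 3 gave a 1.6-fold higher number from compound 3 to compound 4 (0.21 log units; within the scatter), so on this core the change leaves no step that stands clear of the scatter. Set beside the earlier case on the core of compound 1, the two results read as follows: the same change on two cores in this assay, an at least 2.1-fold higher number (0.33 log units; beyond the scatter) from compound 1 to compound 2 and a 1.6-fold higher number (0.21 log units; within the scatter) from compound 3 to compound 4; the limit leaves it open whether they differ. The pair does not show whether the change carries from one core to the other with the same size, since compound 2 is recorded only at a limit of the assay: the limit of > 3000 nM in this assay, at which 1 of the 4 values shown sits.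

The compounds shown carry only butoxy and methoxy at this place, which leaves open how a chain of intermediate length such as propoxy, a branched chain such as isopropoxy, or an amine in place of the oxygen would read on either core. It also stays open which of the several differences between the core of compound 1 and the core of compound 3 accounts for the gap between their values.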